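The source may report more compounds than this note shows. Statements on the series, on what has been measured and on what is new or still open speak of the compounds shown alone.

Compound 3 `CCOC(=O)C(C)Oc1cc(O)c2c(=O)c(O)c(-c3ccc(OC)cc3)oc2c1CC=C(C)C` is the starting point of this step. In a functional assay on A549 cells (Homo sapiens) for cytotoxicity, read by MTT assay (a higher number here means a weaker inhibitor, a lower number a stronger inhibitor), compound 3 gives 26500 nM. Compound 1 `COc1ccc(-c2oc3c(CC=C(C)C)c(OCCCOC(=O)CCCC(=O)O)cc(O)c3c(=O)c2OCCCOC(=O)CCCC(=O)O)cc1` gives 14300 nM in this assay, a number within the usual scatter of that of compound 3, so the two cannot be told apart. For the measured compounds named here, compound 2 `COc1ccc(-c2oc3c(CC=C(C)C)c(OC(C(=O)O)C(=O)O)cc(O)c3c(=O)c2OC(C(=O)O)C(=O)O)cc1` returns only a limit of the assay, > 100000 nM, and is the one value sitting at the limit of > 100000 nM in this assay, at which 1 of the 3 values shown sits. Compound 4 `COc1ccc(-c2oc3c(CC=C(C)C)c(OCC(=O)O)cc(O)c3c(=O)c2O)cc1` is the unmeasured partner of compound 3; the change is carboxymethyl in place of 1-(ethoxycarbonyl)ethyl on an oxygen on an aromatic ring. Going by the values given here, no measured pair isolates this change, so any expectation rests on the spread of the three values shown. The step expected here, a 1.7-fold higher number from compound 3 to compound 4 (0.23 log units; within the scatter), points toward a weaker inhibitor and may exceed the scatter. The estimate for compound 4 in this assay is 45000 nM, with a range from 15000 nM to 100000 nM.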

Compound 4, half-maximal inhibitory concentration: 16700 nM
Estimate against measurement, compound 4: 2.7-fold (0.43 log units) above; the measured number falls inside the stated range.
By their numbers in this assay, from the lowest: compounds 1, 4 and 3 (each within the scatter of the next). At a limit, above all of these: compound 2.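

In this assay, the step of a 1.6-fold lower number from compound 3 to compound 4 (0.20 log units; within the scatter) shows that this oxygen on an aromatic ring accepts either side chain without a change that can be told from scatter. The 1-(ethoxycarbonyl)ethyl group and the smaller carboxymethyl group, which carries a hydrogen-bond donor, cannot be separated by this read-out. Nothing measured here explains this result. As far as these compounds go, the swap alters the chain and its end together, so the contribution of each stays unknown. From the compounds shown here alone, whether an amine or an amide at this oxygen would behave alike also remains open.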